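One Extra Carbon on the Amide Side Chain

The source may report more compounds than this note shows. Statements on the series, on what has been measured and on what is new or still open speak of the compounds shown alone.

Measured in a functional assay on MCF7 cells (Homo sapiens) for antiproliferative activity, read by MTT assay, with a stated time of 72 h; on this read-out lower numbers stand for stronger inhibition and higher numbers for weaker inhibition:
Compound 1, `CC/C=C/C(=O)Nc1cccc(Oc2nc(Nc3cccc(OC)c3)nc3c2CSCC3)c1`: 24200 nM
Compound 2, `COc1cccc(Nc2nc3c(c(Oc4cccc(NC(=O)/C=C/C(C)C)c4)n2)CSCC3)c1`: 21800 nM
Compound 3, `CC/C=C/C(=O)Nc1cccc(Oc2nc(Nc3ccc(OC)nc3)nc3c2CSCC3)c1`: 31500 nM

The three measured compounds share a core and differ in two places. Compound 2 arises from compound 1 through (methyl in place of hydrogen on a saturated chain carbon bound to a double-bonded chain carbon and a saturated chain carbon), and this change gave a 1.1-fold lower number from compound 1 to compound 2 (0.05 log units; within the scatter). Compound 3 arises from compound 1 through (6-methoxypyridin-3-yl in place of 3-methoxyphenyl on a nitrogen on an aromatic ring); its gaps to compound 1 and compound 2 both lie within the scatter, so no order can be drawn among the three.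

Compound 4, `CCC/C=C/C(=O)Nc1cccc(Oc2nc(Nc3ccc(OC)nc3)nc3c2CSCC3)c1`, has not been measured. It differs from compound 3 by methyl in place of hydrogen on a saturated chain carbon, two bonds along the chain from a double-bonded chain carbon. Among the measured compounds shown here, this is the same kind of change as the one between compound 1 and compound 2, though not the same: there the methyl entered on a saturated chain carbon bound to a double-bonded chain carbon and a saturated chain carbon, whereas here it enters on a saturated chain carbon, two bonds along the chain from a double-bonded chain carbon. In this assay a step of similar size is expected, because a 1.1-fold lower number from compound 1 to compound 2 (0.05 log units; within the scatter), and nothing among these compounds points to a larger effect. The expected step is a 1.1-fold lower number from compound 3 to compound 4 (0.04 log units; within the scatter). Compound 4 is thus estimated at 29000 nM, between 13000 nM and 65000 nM.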

Compound 4, half-maximal inhibitory concentration: 26800 nM
The estimate for compound 4 lay 1.1-fold (0.03 log units) above the measured number, within the range that was stated.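

Adding the methyl to the amide side chain of compound 3 gave a 1.2-fold lower number from compound 3 to compound 4 (0.07 log units; within the scatter) in this assay. Set beside the earlier step, the change looks alike on the two cores: the same change on two cores in this assay, a 1.1-fold lower number (0.05 log units; within the scatter) from compound 1 to compound 2 and a 1.2-fold lower number (0.07 log units; within the scatter) from compound 3 to compound 4, 1.1-fold (0.02 log units) apart, within the scatter of two such steps. This shows that the step stayed small when the change moved from the core of compound 1 to the core of compound 3, but it does not show that the methyl itself alters the number, since each step lies within the scatter, and two pairs of compounds with such small steps cannot show whether a larger effect would also carry over from one core to another.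

The side chains shown differ only slightly from one another, so it remains open whether a longer chain, an amine or a carboxylic acid on the amide side chain would move the number beyond the scatter. Going by these compounds, whether any such step would carry over between these two cores is also open.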